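A few compounds are considered here, and "the series" means these few. Any claim that something is new, unique, unknown or untested is made for them only; others in the source may bear on it.

Measured:
- compound 1 `COc1cc2cc(Oc3ccc(NC(=O)Nc4cccc(C(F)(F)F)c4)cc3)c(C)nc2cc1OC`: 10900 nM
- compound 2 `COc1cc2cc(Oc3ccc(NC(=O)Nc4ccc(Cl)c(C(F)(F)F)c4)cc3)c(C)nc2cc1OC`: 6010 nM

In a functional assay on UACC-62 cells (Homo sapiens) for inhibition, read by sulforhodamine B assay, with a stated time of 48 h (on this read-out lower numbers stand for stronger inhibition of growth and higher numbers for weaker inhibition of growth), compound 2 gives 6010 nM, the lowest of the two numbers. Compound 1 gives 10900 nM, and the gap a 1.8-fold lower number from compound 1 to compound 2 (0.26 log units; within the scatter) stays within the scatter. Compound 3 `COc1cc2cc(Oc3ccc(NC(=O)Nc4ccc(Cl)c(Cl)c4)cc3)c(C)nc2cc1OC` differs from compound 2 by chloro in place of trifluoromethyl on an aromatic carbon. Among the compounds with values here, no measured step swaps trifluoromethyl for chloro; the only step known, chloro in place of hydrogen, was within the scatter. A step beyond the scatter is therefore not expected, and compound 3 is estimated at 7000 nM (range 2500 nM to 20000 nM), an expected step of a 1.2-fold higher number from compound 2 to compound 3 (0.07 log units; within the scatter).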

Compound 3, concentration for total growth inhibition: 19200 nM
Compound 3: the middle estimate sits 2.7-fold (0.44 log units) below what was measured; the measured number falls inside the stated range.
By their numbers in this assay, from the lowest: compounds 2, 1 and 3 (each within the scatter of the next, the first and the last beyond it).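

In this assay, within the data shown here, the position meta to a large group proves sensitive to the group it carries: chloro in place of trifluoromethyl, ortho to a chloro group, gives the first step beyond the scatter, though a modest one (a 3.2-fold higher number from compound 2 to compound 3 (0.50 log units; beyond the scatter)). Read as a whole-ring change, 3,4-dichlorophenyl in place of 3-(trifluoromethyl)phenyl stays within the scatter (a 1.8-fold higher number from compound 1 to compound 3 (0.25 log units; within the scatter)). No measurement offered here accounts for the step.

Open, from the compounds shown here alone, is where a nitrile, a methoxy or an amine at this position would fall relative to compound 2 and compound 3. Also open, going by these compounds, is whether the step holds when no chloro group stands ortho to the position.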